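The source may report more compounds than this note shows. Statements on the series, on what has been measured and on what is new or still open speak of the compounds shown alone.

Working notes on the series in a functional assay on the whole organism (strain albino) for inhibition, with Rattus norvegicus as the target, read by paw edema, with stated times of 30 min and 3 h, at a dose of 100 mg/kg by the oral route; on this read-out higher numbers stand for more inhibition at the one dose given (going by the name of the read-out) and lower numbers for less inhibition. Compound 1 `Nc1ccc(C(=O)/C=C/c2ccco2)cc1` gives 42%. Compound 2 `O=C(CBr)Nc1ccc(C(=O)/C=C/c2ccco2)cc1` gives 41%, and a number 1 percentage points lower from compound 1 to compound 2 (within the scatter) stays within the scatter. Compound 3 `CC(Br)C(=O)Nc1ccc(C(=O)/C=C/c2ccc(Cl)cc2)cc1` gives 59%, the highest of the three numbers, beyond the scatter from both compound 1 and compound 2. Compound 4 `CC(Br)C(=O)Nc1ccc(C(=O)/C=C/c2ccco2)cc1` is not yet measured and differs from compound 3 in one place: furan-2-yl in place of 4-chlorophenyl on a double-bonded chain carbon bound to a double-bonded chain carbon. Going by the values given here, no measured pair differs by this exchange alone; the step from compound 1 to compound 2 concerns the amide and does not bear on it. Compound 1 and compound 2 carry the furan-2-yl and lie below compound 3, so a downward step is expected for compound 4 in this assay, a number 14 percentage points lower from compound 3 to compound 4 (beyond the scatter). Compound 4 is estimated at 45%, within 32% to 60%.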

Compound 4, a percentage reported as inhibition, in the whole organism at one dose (the size of the read-out at that dose, not a potency): 42%
The estimate for compound 4 lay 3 percentage points above the measured number; the range from low to high includes it.
By their numbers in this assay, from the lowest: compounds 2, 1 and 4 (each within the scatter of the next); then compound 3.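

In this assay, the position on a double-bonded chain carbon bound to a double-bonded chain carbon now has a measured pair: furan-2-yl in place of 4-chlorophenyl gives a number 17 percentage points lower from compound 3 to compound 4 (beyond the scatter). With furan-2-yl held, the groups on the nitrogen do not separate: the added methyl gives a number 1 percentage points higher from compound 2 to compound 4 (within the scatter), and (1-bromoethyl)carbonyl in place of hydrogen gives no change at the digits printed from compound 1 to compound 4 (within the scatter). Nothing on hand explains the step at this position.

From the compounds shown here alone, whether the step follows the chlorine or the ring itself stays open; an unsubstituted phenyl or a thiophen-2-yl at this place would separate the two.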